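Shortening the Chain End of Compound 2

The compounds below may be only part of what the source reports. "The series", "measured", "known", "first", "only" and "open" are said of these compounds alone.

Compound 1: `CCCCCCCC#CC#CCO`, 5.48 ug/mL in a functional assay on A549 cells (Homo sapiens) for cytotoxicity; a lower number here means that less compound is needed, a higher number that more compound is needed for the effect
Compound 2: `C=CCCCCCCCC#CC#CCOCC(=O)OC`, > 30 ug/mL

In this assay compound 1 gives 5.48 ug/mL. For compound 2 the result is only a limit of the assay, > 30 ug/mL, not a number; this is the limit of > 30 ug/mL in this assay, at which 1 of the 2 values shown sits. On the numbers shown, compound 2 thus stands at the limit, and how far beyond it the real value lies cannot be read from the data.

Compound 3, `CCCCCCCC#CC#CCOCC(=O)OC`, has not yet been tested. It differs from compound 2 in one place: hydrogen in place of vinyl on a saturated chain carbon, seven bonds along the chain from a triple-bonded carbon. Among the compounds with values here, no measured pair shows a step of this kind, so both the size and the direction of the change are uncertain. A modest downward step is expected, an at least 1.5-fold lower number from compound 2 to compound 3 (0.17 log units; that floor lies within the scatter), while a second limit remains quite possible. The estimate for compound 3 in this assay is 20 ug/mL, within a range from 6 ug/mL to 70 ug/mL.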

Compound 3, concentration for half-maximal effect: > 30 ug/mL
Compound 3 gave a limit, no number; the forecaster's own chance of this, stated with the estimate: 45%; middle value at least 1.5-fold (0.17 log units) from the limit.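

Compound 3 has lost the vinyl, and its chain end now matches that of compound 1. The two differ in one place only: (methoxycarbonyl)methyl in place of hydrogen on an oxygen on a saturated carbon. In this assay, within the data shown here, this one change gives an at least 5.4-fold higher number from compound 1 to compound 3 (0.73 log units; beyond the scatter), the first readable step, and it shows that substitution on this oxygen alone is enough to move the result well away from that of compound 1. The effect of removing the vinyl cannot be read, because compound 2 and compound 3 both give only a limit, not a number: the limit of > 30 ug/mL in this assay, at which 2 of the 3 values shown sit.

The compounds shown leave open how far beyond the limit the real value of compound 3 lies, and whether the vinyl has any effect at all on this chain. They also leave open whether the higher number depends on the methyl ester or on any group placed on that oxygen, which a carboxylic acid or a plain methyl ether in the same place could help to separate.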